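A few compounds are considered here, and "the series" means these few. Any claim that something is new, unique, unknown or untested is made for them only; others in the source may bear on it.

Measured so far in a physicochemical assay for solubility, in phosphate buffer, with a stated time of 18 h, at pH 7.4; on this read-out higher numbers stand for higher solubility and lower numbers for lower solubility:
compound 1 `COc1cc2ncnc(-n3nc(-c4ccc(Cl)cc4)nc3N)c2cc1OC` gives 1000 nM
compound 2 `COc1cc2nc(N)nc(-n3nc(-c4ccccn4)nc3N)c2cc1OC` gives 27000 nM
compound 3 `COc1cc2ncnc(-n3nc(-c4ccccn4)nc3N)c2cc1OCCCN(C)C` gives 53000 nM

Compound 3 holds the highest of the three numbers. Its nearest neighbour is compound 2, whose number lies within the scatter of it, so the two cannot be ordered against each other. Its furthest neighbour is compound 1, whose number lies well beyond the scatter, so compound 3 does stand clearly above compound 1 in this assay. Among the compounds with values here, no two measured compounds differ in a single place, so the measured set offers no direct step to lean on for the change now at hand.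

Compound 4 `COc1cc2ncnc(-n3nc(-c4ccccn4)nc3N)c2cc1OCCCNC(=O)OCC(F)(F)F` differs from compound 3 in one place: ((2,2,2-trifluoroethoxy)carbonyl)amino in place of dimethylamino on a saturated chain carbon, three bonds along the chain from an oxygen on an aromatic ring. On the saturated chain the group that leaves has no hydrogen-bond donor and the group that enters brings one donor and two acceptors together with three fluorine atoms. Within the data shown here, no measured pair shows what such a swap does, so the expectation is loose. The step from compound 3 to compound 4 is expected to be downward and beyond the scatter, a 13-fold lower number from compound 3 to compound 4 (1.12 log units; beyond the scatter). Compound 4 is estimated at 4000 nM, within a range from 600 nM to 25000 nM.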

Compound 4, solubility: 100 nM
For compound 4 the middle estimate is 40-fold (1.60 log units) above the measured one, and the stated range ends above it.
By their numbers in this assay, from the lowest: compound 4; then compound 1; then compounds 2 and 3 (each within the scatter of the next).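

In this assay, ((2,2,2-trifluoroethoxy)carbonyl)amino in place of dimethylamino at the end of the 3-(dimethylamino)propyl chain gives a large step, beyond the scatter (a 530-fold lower number from compound 3 to compound 4 (2.72 log units; beyond the scatter)). Within the data shown here, this is the first single-place change readable, and it shows that the group at this chain end can move the read-out strongly while the shared core and the chain stay unchanged. No measured evidence on hand accounts for the size of this step.

Going by these compounds, it remains open whether the step follows from the departure of dimethylamino or from the particular group that enters, which a morpholine, a primary amine or a carboxylic acid on the same chain would help to separate. On these data alone, it is also open whether the same exchange would give a step of similar size on the core of compound 2.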